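The compounds below may be only part of what the source reports. "The series", "measured", "known", "first", "only" and "open" are said of these compounds alone.

Two members of the series carry the shared core of compound 1, `COc1cc(NC(C)CCCNC(=O)NC(c2ccccc2)c2ccccc2)c2ncccc2c1`, and differ only in the group on the urea nitrogen. In an ADME assay on HEL cells (Homo sapiens) for cytotoxicity (a lower number here means that less compound is tolerated, a higher number that more compound is tolerated), compound 1 gives only a limit, > 100000 nM, and no number. For the measured compounds named here, compound 2, `COc1cc(NC(C)CCCNC(=O)NC2CCCCC2)c2ncccc2c1`, gives in this assay a value of 94000 nM, the only number in hand. The remaining entry, belonging to compound 1, is the limit of > 100000 nM in this assay, at which 1 of the 2 values shown sits. Going by the values given here, no pair of measured compounds differs in one place, so no measured step exists to set a scale for the next change.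

Compound 3, `COc1cc(NC(C)CCCNC(=O)NCC2CCCCC2)c2ncccc2c1`, is not yet measured. It differs from compound 2 by cyclohexylmethyl in place of cyclohexyl on an amide-type nitrogen. With nothing to compare against, the change from compound 2 to compound 3 is expected to stay within the scatter of this assay, a 1.0-fold lower number from compound 2 to compound 3 (0.02 log units; within the scatter). Compound 3 is accordingly estimated at about 90000 nM in this assay, with a range from 40000 nM to 180000 nM.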

Compound 3, half-maximal cytotoxic concentration: 74000 nM
The estimate for compound 3 lay 1.2-fold (0.09 log units) above the measured number; low and high end bracket the measured number.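

On the amide-type nitrogen there is now a first measured step: in this assay, cyclohexylmethyl in place of cyclohexyl gives a 1.3-fold lower number from compound 2 to compound 3 (0.10 log units; within the scatter). This position therefore accepts this one extension of the substituent with the two values staying within the scatter of each other, and that step gives the series its first scale for changes here. Compound 1 remains a limit and not a number, so steps to it cannot be read: the limit of > 100000 nM in this assay, at which 1 of the 3 values shown sits.

Going by these compounds, a single step at one position sets no trend, and it remains open whether a longer chain such as cyclohexylethyl would also stay within the scatter. The compounds shown also leave open what a substituent carrying an amine or a carboxylic acid would do at this nitrogen in this assay.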